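Cytotoxicity of triazole-linked chromones: a chloro for fluoro swap

The compounds below may be only part of what the source reports. "The series", "measured", "known", "first", "only" and "open" are said of these compounds alone.

Compounds measured so far:
compound 1, `O=c1ccoc2cc(OCc3cn(Cc4ccccc4)nn3)ccc12`, > 300000 nM in an ADME assay on L02 cells (Homo sapiens) for cytotoxicity, read by MTT assay, with a stated time of 48 h; on this read-out higher numbers stand for weaker inhibition and lower numbers for stronger inhibition
compound 2, `Cc1ccccc1Cn1cc(COc2ccc3c(=O)ccoc3c2)nn1`, > 300000 nM
compound 3, `O=c1ccoc2cc(OCc3cn(Cc4cccc(F)c4)nn3)ccc12`, > 300000 nM

Each of these values is a limit of the assay, not a number. Compound 1 in this assay gives > 300000 nM, which is a limit. Compound 2 gives > 300000 nM, again a limit. Compound 3 gives > 300000 nM, also a limit. Accordingly the step that the two limits leave unreadable from compound 1 to compound 2 cannot be sized, nor can a step that the two limits leave unreadable from compound 1 to compound 3 or a step that the two limits leave unreadable from compound 2 to compound 3. The common picture is the limit of > 300000 nM in this assay, at which 3 of the 3 values shown sit.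

Compound 4, `O=c1ccoc2cc(OCc3cn(Cc4cccc(Cl)c4)nn3)ccc12`, has not yet been measured. It differs from compound 3 by chloro in place of fluoro on an aromatic carbon. Among the measured compounds shown here, none of the measured steps gives a readable size, so there is no basis for expecting a change beyond the scatter. For compound 4 the account therefore expects a value that again sits at or past the limit, estimated at 400000 nM with a range from 150000 nM to 1000000 nM. The expected step is a step that the limit leaves unreadable from compound 3 to compound 4.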

Compound 4, half-maximal inhibitory concentration: > 300000 nM
Compound 4: only a limit was reported (the forecaster's own chance of this, stated with the estimate: 85%); the middle value does not contradict the limit.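

Compound 4 gives > 300000 nM in this assay, which is a limit of the assay. Its steps from compound 1, compound 2 and compound 3 therefore cannot be read: the limit of > 300000 nM in this assay, at which 4 of the 4 values shown sit. The compounds shown leave open whether these four differ at all in this assay.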